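Dienone series: methoxy analogue of compound 1

The source may hold more compounds than are shown below. What is called first, only, known or untested is meant among the compounds shown, and "the series" means these compounds.

For the measured compounds named here, compound 1 `CC1=C(/C=C/C(=O)/C=C/c2ccccc2)C(C)(C)CCC1` stands highest of the three numbers so far: in a functional assay on HeLa cells (Homo sapiens) for cytotoxicity, read by sulforhodamine B assay, with a stated time of 48 h (on this read-out lower numbers stand for stronger inhibition and higher numbers for weaker inhibition), compound 1 gives 70200 nM. Its chloro analogue compound 2 `CC1=C(/C=C/C(=O)/C=C/c2ccc(Cl)cc2)C(C)(C)CCC1` gives 33200 nM, and its nitro analogue compound 3 `CC1=C(/C=C/C(=O)/C=C/c2ccc([N+](=O)[O-])cc2)C(C)(C)CCC1` gives 28700 nM. Both substitutions give modest steps, a 2.1-fold lower number from compound 1 to compound 2 (0.33 log units; beyond the scatter) and a 2.4-fold lower number from compound 1 to compound 3 (0.39 log units; beyond the scatter), while between them a 1.2-fold lower number from compound 2 to compound 3 (0.06 log units; within the scatter). Compound 4 `COc1ccccc1/C=C/C(=O)/C=C/C1=C(C)CCCC1(C)C` differs from compound 1 by methoxy in place of hydrogen on an aromatic carbon. Going by the values given here, no measured step adds methoxy, and none places a group ortho to a large group, so the bearing of the earlier steps is indirect. Because a 2.1-fold lower number from compound 1 to compound 2 (0.33 log units; beyond the scatter) and a 2.4-fold lower number from compound 1 to compound 3 (0.39 log units; beyond the scatter) both lowered the number only modestly, a step of similar or smaller size is expected for compound 4, a 1.4-fold lower number from compound 1 to compound 4 (0.15 log units; within the scatter). Compound 4 is estimated in this assay at 50000 nM, ranging from 20000 nM to 120000 nM.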

Compound 4, half-maximal inhibitory concentration: 88200 nM
Estimate against measurement, compound 4: 1.8-fold (0.25 log units) below; the range from low to high includes it.
By their numbers in this assay, from the lowest: compounds 3 and 2 (each within the scatter of the next); then compounds 1 and 4 (each within the scatter of the next).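

In this assay methoxy on this aromatic carbon, ortho to a large group, gives no step beyond the scatter (a 1.3-fold higher number from compound 1 to compound 4 (0.10 log units; within the scatter)). The lowering seen with chloro in compound 2 and nitro in compound 3 therefore does not extend to every group placed on this aromatic ring. Nothing at hand accounts for this result.

Still open, on these data alone, is whether methoxy elsewhere on the ring would give the same result. Also open, as far as these compounds go, is whether an amine or a carboxylic acid at this position would move the number beyond the scatter.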